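Replacing Amino with Hydroxy on the Chain

The source may hold more compounds than are shown below. What is called first, only, known or untested is meant among the compounds shown, and "the series" means these compounds.

Of the compounds shown here, three with a shared core have been measured in a physicochemical assay for lipophilicity, read by HPLC; a higher number here means a more lipophilic compound, a lower number a more polar compound. Compound 1 `Cc1ccsc1C(=CCCN(C)C(CCN)C(=O)NCc1ccccc1)c1sccc1C` gives 5.5. Compound 2 `Cc1ccc(CNC(=O)C(CCN)N(C)CCC=C(c2sccc2C)c2sccc2C)cc1` gives 6.61, and compound 3 `Cc1ccsc1C(=CCCN(C)C(CCN)C(=O)NCc1ccc(F)cc1)c1sccc1C` gives 6.45. Among these, compound 3 has the second highest number: its nearest neighbour is compound 2, which lies within the scatter, and the furthest is compound 1, which lies beyond it. The measured steps were a number 1.11 log units higher from compound 1 to compound 2 (beyond the scatter), a number 0.95 log units higher from compound 1 to compound 3 (beyond the scatter) and a number 0.16 log units lower from compound 2 to compound 3 (within the scatter).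

The next compound, compound 4 `Cc1ccsc1C(=CCCN(C)C(CCO)C(=O)NCc1ccc(F)cc1)c1sccc1C`, differs from compound 3 in one place: hydroxy in place of amino on a saturated chain carbon, three bonds along the chain from an amine nitrogen and a carbonyl carbon. Within the data shown here, none of the measured steps touches this part of the molecule; all of them concern groups on the aromatic ring, so they give no direct guide to the size or direction of this change. Among the measured compounds shown here, the expectation therefore rests on the change itself, with no step to anchor it, and a wide range is appropriate. The estimated step is a number 0.55 log units higher from compound 3 to compound 4 (beyond the scatter). For compound 4 the expected value in this assay is 7, with a range from 6.2 to 7.8.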

Compound 4, partition coefficient: 5.87
Estimate against measurement, compound 4: 1.13 log units above; the measured number lies below the stated range.
By their numbers in this assay, from the lowest: compound 1; then compound 4; then compounds 3 and 2 (each within the scatter of the next).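

Among these compounds, this is the first change on the saturated chain rather than on the aromatic ring, and in this assay exchanging amino for hydroxy at this place gives a number 0.58 log units lower from compound 3 to compound 4 (beyond the scatter), so the position does respond to what it carries. The exchange is small on paper: a single nitrogen gives way to a single oxygen, the counts of hydrogen-bond donors and acceptors stay the same, and neither group carries a net charge, yet the step still lies beyond the scatter, which shows that those counts alone do not settle the reading at this position. No measurement shown here explains why the number moves in this direction.

The compounds shown carry only amino and hydroxy at this place, so it remains open how a methoxy group, a carboxylic acid or a longer chain would read there. Among the compounds shown here, the exchange is also seen only in the fluoro compound, and whether it gives a similar step alongside the methyl group of compound 2 or the unsubstituted ring of compound 1 remains an open question.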